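From a 3-methoxyphenyl to a 2-ethoxyphenyl amine

The source may hold more compounds than are shown below. What is called first, only, known or untested is meant among the compounds shown, and "the series" means these compounds.

Measured in a functional assay on MCF7 cells (Homo sapiens) for inhibition, read by sulforhodamine B assay; on this read-out lower numbers stand for stronger inhibition and higher numbers for weaker inhibition:
- compound 1 `O=C1C(Nc2ccc(I)cc2)=CC(=O)c2c1nc1n2[C@H]2OC[C@@H](O)[C@H]2OC1`: 3890 nM
- compound 2 `COc1cccc(NC2=CC(=O)c3c(nc4n3[C@H]3OC[C@@H](O)[C@H]3OC4)C2=O)c1`: 3830 nM

Going by the values given here, compound 2 stands level with compound 1, the only other compound with a number. Their values lie within the scatter of each other. The next structure, compound 3 `CCOc1ccccc1NC1=CC(=O)c2c(nc3n2[C@H]2OC[C@@H](O)[C@H]2OC3)C1=O`, keeps the shared core and changes one group: 2-ethoxyphenyl in place of 3-methoxyphenyl on an amine nitrogen. In words, this is 2-ethoxyphenyl in place of 3-methoxyphenyl on an amine nitrogen.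

Among the compounds with values here, only one measured step bears on this change. That step, a 1.0-fold lower number from compound 1 to compound 2 (0.01 log units; within the scatter), put 3-methoxyphenyl in place of 4-iodophenyl on the same amine nitrogen. Within the data shown here, one step is thin evidence, and no measured compound carries a 2-ethoxyphenyl group, so the range must stay wide. Resting on that single step within the scatter, no change beyond the scatter is expected in this assay. The expected step is a 1.0-fold lower number from compound 2 to compound 3 (0.00 log units; within the scatter). Compound 3 is estimated at 3800 nM, with an expected range of 1700 nM to 8500 nM.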

Compound 3, half-maximal inhibitory concentration: > 4000 nM
Compound 3 gave a limit, no number; the forecaster's own chance of this, stated with the estimate: 5%; at least 1.0-fold (0.02 log units) between middle value and limit.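

In this assay compound 3 gives > 4000 nM, which is a limit of the assay and not a number. The step read from it is an at least 1.0-fold higher number from compound 2 to compound 3 (0.01 log units; that floor lies within the scatter), and the matching step is an at least 1.0-fold higher number from compound 1 to compound 3 (0.01 log units; that floor lies within the scatter); both floors lie within the scatter, so the 2-ethoxyphenyl group on the amine nitrogen is not shown to differ from 3-methoxyphenyl or 4-iodophenyl, though the true value of compound 3 has no upper bound here. What is new is that this position now carries a group for which the assay returns only a limit rather than a number: the limit of > 4000 nM in this assay, at which 1 of the 3 values shown sits.

As far as these compounds go, how far compound 3 truly lies from compound 1 and compound 2 stays open, as does whether its limit reflects any real change at all. Also open, from the compounds shown here alone, is whether a 2-methoxyphenyl or a 3-ethoxyphenyl group on the same amine nitrogen would read like compound 2 or like compound 3, which would help separate the effect of the chain from that of its place on the ring.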